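The source may hold more compounds than are shown below. What is called first, only, known or untested is meant among the compounds shown, and "the series" means these compounds.

For the measured compounds named here, in a functional assay on L1210 cells (Mus musculus) (a higher number here means a weaker inhibitor, a lower number a stronger inhibitor), compound 2 `O=c1[nH]c(=O)n([C@@H]2O[C@@H]3COP(=O)(O)O[C@H]3[C@H]2O)cc1F` gives 0.34 ug/mL, the lowest of the two numbers measured so far. Its only companion, compound 1 `O=c1[nH]c(=O)n([C@@H]2O[C@@H]3COP(=O)(O)O[C@H]3[C@H]2O)cc1I`, gives 315 ug/mL in this assay. The two differ only in the halogen on the shared core, and that single step, fluoro in place of iodo on an aromatic carbon, brought a 930-fold lower number from compound 1 to compound 2 (2.97 log units; beyond the scatter). Compound 3 `O=c1[nH]c(=O)n([C@@H]2O[C@@H]3COP(=O)(O)O[C@H]3[C@H]2O)cc1Br` has not yet been measured; it differs from compound 2 as follows: bromo in place of fluoro on an aromatic carbon. Going by the values given here, the one measured step bears on this directly: exchanging iodo for fluoro at this carbon gave a very large drop, so returning a halogen that is heavier than fluorine, though lighter than iodine, to the same place is expected to raise the number again, most likely to a point somewhere short of where compound 1 stands. Among the compounds with values here, no measured pair fixes the size of this particular step, so the expectation is broad. Compound 3 is therefore expected to give about 30 ug/mL in this assay, within 3 ug/mL to 300 ug/mL, which would mean a step of an 88-fold higher number from compound 2 to compound 3 (1.95 log units; beyond the scatter).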

Compound 3, concentration for 50% inhibition: 315 ug/mL
Compound 3: the middle estimate sits 11-fold (1.02 log units) below what was measured; the whole stated range lies below it.
By their numbers in this assay, from the lowest: compound 2; then compounds 1 and 3 (each within the scatter of the next).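

In this assay, the heavier halogens on this aromatic carbon cannot be told apart: bromo in place of iodo gives no change at the digits printed from compound 1 to compound 3 (within the scatter), so the high number of compound 1 is not peculiar to iodo. Fluoro is the one that stands apart, since bromo in place of fluoro gives a 930-fold higher number from compound 2 to compound 3 (2.97 log units; beyond the scatter), a step as large as the one seen earlier with iodo, and the lighter of the two heavy halogens recovers none of the low number of compound 2. Across these three compounds the result therefore looks less like a gradual trend down the halogens than a division between fluoro on one side and bromo and iodo on the other, and nothing available explains that division.

Chloro, the remaining common halogen, would show on which side of this division the next halogen after fluoro falls. The compounds shown also leave open whether fluoro itself is needed, a question that a plain hydrogen, a methyl group or an amine on the same carbon of the shared core would help to answer.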